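This account rests on a few compounds, and the source may have more. Where it says the series, first, only, none or still open, it means among the compounds named here.

Values in a functional assay (Pituitary gland cell) with Rattus norvegicus as the target (on this read-out lower numbers stand for an effect already at smaller amounts and higher numbers for an effect only at larger amounts of compound), for the three measured compounds

Compound 1 `CC(C)(N)CC(=O)N[C@@H]1CCc2ccccc2N(Cc2ccc(-c3ccccc3C(N)=O)cc2)C1=O` gives 0.08 uM
Compound 2 `CCNC(=O)c1ccccc1-c1ccc(CN2C(=O)[C@H](NC(=O)CC(C)(C)N)CCc3ccccc32)cc1` gives 0.09 uM
Compound 3 `CC(C)(N)CC(=O)N[C@@H]1CCc2ccccc2N(Cc2ccc(-c3ccccc3C(=O)NCCCO)cc2)C1=O` gives 0.4 uM

Compound 2 at 0.09 uM sits with compound 1 at the low end of the three numbers, and the two lie within the scatter of each other. Compound 4 `CC(C)(N)CC(=O)N[C@@H]1CCc2ccccc2N(Cc2ccc(-c3ccccc3C(=O)NCCCCO)cc2)C1=O` has not been measured. It departs from compound 2 by 2-hydroxyethyl in place of hydrogen on a saturated chain carbon, two bonds along the chain from an amide-type nitrogen so that ethyl gives way to 4-hydroxybutyl. The closest measured change is the step of a 4.4-fold higher number from compound 2 to compound 3 (0.65 log units; beyond the scatter) for hydroxymethyl at that same place, which is modest and beyond the scatter. The step of a 5.0-fold higher number from compound 1 to compound 3 (0.70 log units; beyond the scatter) for 3-hydroxypropyl points the same way, while the step of a 1.1-fold higher number from compound 1 to compound 2 (0.05 log units; within the scatter) for ethyl stays within the scatter. Among the compounds with values here, no measurement yet covers the 4-hydroxybutyl chain, so the expectation rests on compound 3 alone. The expected change is a 4.4-fold higher number from compound 2 to compound 4 (0.65 log units; beyond the scatter) and would be a modest move toward a higher number. For compound 4 the estimated value is 0.4 uM in this assay with an expected range from 0.15 uM to 1 uM around it.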

Compound 4, concentration for half-maximal effect: 0.01 uM
For compound 4 the middle estimate is 40-fold (1.60 log units) above the measured one; the whole stated range lies above it.
By their numbers in this assay, from the lowest: compound 4; then compounds 1 and 2 (each within the scatter of the next); then compound 3.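

In this assay, the step of an 8.0-fold lower number from compound 1 to compound 4 (0.90 log units; beyond the scatter) shows that the amide nitrogen can carry a chain that lowers the number, which neither ethyl nor 3-hydroxypropyl had shown at this position. The step of a 9.0-fold lower number from compound 2 to compound 4 (0.95 log units; beyond the scatter) adds that extending the ethyl to 4-hydroxybutyl lowers the number, whereas the shorter hydroxy-ended chain of compound 3 had raised it. Hydroxy-ended chains therefore do not act alike here, as the step of a 40-fold lower number from compound 3 to compound 4 (1.60 log units; beyond the scatter) makes plain, and the evidence offers no reason for this reversal.

From the compounds shown here alone, it remains open whether a longer chain than 4-hydroxybutyl would lower the number further or raise it again. Also open is whether the terminal hydroxy matters, since a plain butyl chain, or one ending in an amine or a carboxylic acid, is not among these compounds.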